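A few compounds are considered here, and "the series" means these few. Any claim that something is new, unique, unknown or untested is made for them only; others in the source may bear on it.

Compound 1 `O=C(O)COc1cc(Cl)c(C(=O)Nc2cccc(-c3nc4ccccc4s3)c2)cc1[N+](=O)[O-]` gives > 25000 nM
Compound 2 `O=C(Nc1cccc(-c2nc3ccccc3s2)c1)c1cc([N+](=O)[O-])ccc1Cl` gives > 27000 nM

In an ADME assay on BJ cells (Homo sapiens) for cytotoxicity, with a stated time of 72 h (a lower number here means that less compound is needed, a higher number that more compound is needed for the effect), compound 2 stands at a limit, not at a number (> 27000 nM). Compound 1 also stands at a limit (> 25000 nM). Compound 3 `O=C(Nc1cccc(-c2ccccc2)c1)c1cc([N+](=O)[O-])ccc1Cl` differs from compound 2 in one place (phenyl in place of 1,3-benzothiazol-2-yl on an aromatic carbon). For the measured compounds named here, the only measured step (a step that the two limits leave unreadable from compound 1 to compound 2) is a different change and has no readable size, so it offers no size to carry over. No step beyond the scatter is therefore expected in this assay and no direction can be given. The step expected here is small (a number no higher from compound 2 to compound 3 (the limit leaves the size open)). For compound 3 the estimate is 27000 nM with an expected range from 12000 nM to 50000 nM and a limit may well be all that is expected.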

Compound 3, half-maximal effective concentration: > 27000 nM
Compound 3 gave a limit, no number; the forecaster's own chance of this, stated with the estimate: 85%; the middle value lies on the limit itself.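

For the compounds shown here, compound 2 and compound 3 both give only a limit in this assay, so no step between them can be read. The compounds shown leave open where the half-maximal effective concentration of any of them actually lies.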